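Second fluorine enters the aniline of compound 3

A few compounds are considered here, and "the series" means these few. Any claim that something is new, unique, unknown or untested is made for them only; others in the source may bear on it.

Among three compounds built on one shared core, compound 3 `Fc1cccc(Nc2nc3nonc3nc2Nc2ccccc2F)c1` gives the lowest number in an assay on mitochondria from L6 cells (Rattus norvegicus) for activation, with a stated time of 90 min (a higher number here means that more compound is needed for the effect, a lower number that less compound is needed), at 190 nM. Compound 1 `FC(F)(F)c1cccc(Nc2nc3nonc3nc2Nc2cccc(C(F)(F)F)c2)c1` gives 700 nM, and compound 2 `Fc1ccccc1Nc1nc2nonc2nc1Nc1ccccc1` gives 2200 nM. Among the compounds with values here, the only single-point step measured, a 12-fold lower number from compound 2 to compound 3 (1.06 log units; beyond the scatter), came from fluoro in place of hydrogen on an aromatic carbon. Compound 4 `Fc1ccc(Nc2nc3nonc3nc2Nc2ccccc2F)c(F)c1` differs from compound 3 by 2,4-difluorophenyl in place of 3-fluorophenyl on a nitrogen on an aromatic ring. Within the data shown here, that earlier step bears on this change only loosely, since no measured pair shows this exchange of groups by itself. A modest step, if any beyond the scatter, is therefore expected for compound 4 in this assay, a 1.3-fold lower number from compound 3 to compound 4 (0.10 log units; within the scatter). The value of compound 4 is estimated at 150 nM, within a range from 50 nM to 500 nM.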

Compound 4, half-maximal effective concentration: 300 nM
Compound 4: the middle estimate sits 2.0-fold (0.30 log units) below what was measured; low and high end bracket the measured number.
By their numbers in this assay, from the lowest: compounds 3 and 4 (each within the scatter of the next); then compound 1; then compound 2.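

In this assay, the step to the 2,4-difluorophenyl group gives a 1.6-fold higher number from compound 3 to compound 4 (0.20 log units; within the scatter), so on this nitrogen that group and 3-fluorophenyl cannot be told apart. Against the plain phenyl group the picture differs, with a 7.3-fold lower number from compound 2 to compound 4 (0.87 log units; beyond the scatter), which shows that a second fluorinated ring on this nitrogen, and not only 3-fluorophenyl, goes with a number beyond the scatter from that of compound 2. Nothing shown here accounts for either step. Still open, as far as these compounds go, is whether a methoxy group or an amine on this ring, in place of fluorine, would hold the number in this range in this assay.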